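Oxane attachment swap on the sulfonyl sulfur

A few compounds are considered here, and "the series" means these few. Any claim that something is new, unique, unknown or untested is made for them only; others in the source may bear on it.

In a physicochemical assay for solubility, in phosphate buffer, with a stated time of 24 h, at pH 7.4, tested at 100 uM (a higher number here means a more soluble compound, a lower number a less soluble compound), compound 3 (`O=C(NCc1ccc(S(=O)(=O)C2CCOCC2)cc1)N1Cc2ccncc2C1`) gives 206000 nM as its value, and compound 2 (`CCCn1cc(S(=O)(=O)c2ccc(CNC(=O)N3Cc4ccncc4C3)cc2)cn1`) gives 105000 nM as its value. The gap is a 2.0-fold higher number from compound 2 to compound 3 (0.29 log units; within the scatter) and does not separate them. Both stand clear of compound 1 (`O=C(NCc1ccc(S(=O)(=O)c2cccc(C(F)(F)F)c2)cc1)N1Cc2ccncc2C1`), which gives 10000 nM in the same measurement. The steps away from it are large, namely an 11-fold higher number from compound 1 to compound 2 (1.02 log units; beyond the scatter) and a 21-fold higher number from compound 1 to compound 3 (1.31 log units; beyond the scatter) on the same sulfonyl sulfur.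

Compound 4 (`O=C(NCc1ccc(S(=O)(=O)C2CCCOC2)cc1)N1Cc2ccncc2C1`) differs from compound 3 by oxan-3-yl in place of oxan-4-yl on a sulfonyl sulfur with oxan-3-yl in place of oxan-4-yl on a sulfonyl sulfur. Among the compounds with values here, no measured step covers such a change, and both large steps start from 3-(trifluoromethyl)phenyl, which plays no part here. With a 2.0-fold higher number from compound 2 to compound 3 (0.29 log units; within the scatter) as the closest guide, no step beyond the scatter is expected in this assay for this pair. The expected move is a 1.2-fold lower number from compound 3 to compound 4 (0.08 log units; within the scatter) and its direction is not settled by the data. Compound 4 is estimated at 170000 nM with an expected range of 85000 nM to 300000 nM around that middle.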

Compound 4, solubility: 208000 nM
Compound 4: middle estimate off by 1.2-fold (0.09 log units), on the low side, within the range that was stated.
By their numbers in this assay, from the lowest: compound 1; then compounds 2, 3 and 4 (each within the scatter of the next).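

In this assay, putting oxan-3-yl in place of oxan-4-yl is the only change among these compounds that keeps the same atoms and alters only how they are joined, and it gives a 1.0-fold higher number from compound 3 to compound 4 (0.00 log units; within the scatter). The oxan-3-yl compound also stays within the scatter of the 1-propyl-1H-pyrazol-4-yl compound, with a 2.0-fold higher number from compound 2 to compound 4 (0.30 log units; within the scatter), and stands well clear of the 3-(trifluoromethyl)phenyl compound, with a 21-fold higher number from compound 1 to compound 4 (1.32 log units; beyond the scatter), so this read-out does not separate the two oxane attachments on the sulfonyl sulfur. No measurement at hand offers an explanation for this result.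

Open, on these data alone, is whether a ring carrying an amine, such as piperidin-4-yl, or a carboxylic acid on the sulfonyl sulfur would read with compounds 2, 3 and 4 or apart from them. Also open, as far as these compounds go, is how oxetan-3-yl, a smaller oxygen ring, would read in the same place.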